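The source may hold more compounds than are shown below. What is called first, only, known or untested is meant among the compounds shown, and "the series" means these compounds.

Working notes on the series. Compound 1 `COc1cc(-c2cc(/C=C/C(=O)c3ccc(N)cc3)[nH]n2)cc(OC)c1OC` is the reference point; compound 2 `COc1ccc(-c2cc(/C=C/C(=O)c3ccc(N)cc3)[nH]n2)cc1OC` and compound 3 `COc1cc(C(=O)/C=C/c2cc(-c3cc(OC)c(OC)c(OC)c3)n[nH]2)cc(OC)c1OC` sit beside it. In a functional assay on UACC-62 cells (Homo sapiens) for cytotoxicity, read by sulforhodamine B assay, with a stated time of 48 h, tested at 100 uM (a higher number here means a weaker effect of the compound at the concentration tested, a lower number a stronger effect), compound 1 gives -92%, compound 2 gives -86%, and compound 3 gives -97%. Compound 1 thus stands second highest of the three numbers, with compound 3 nearest and compound 2 furthest, both gaps within the scatter. For the measured compounds named here, the only one-place step measured, a number 6 percentage points higher from compound 1 to compound 2 (within the scatter), lies within the scatter. Compound 4 `COc1cc(-c2cc(/C=C/C(=O)c3ccc(F)c(F)c3)[nH]n2)cc(OC)c1OC` is to be measured in this assay; it differs from compound 1 by 3,4-difluorophenyl in place of 4-aminophenyl on a carbonyl carbon. Going by the values given here, no measured step touches the carbonyl-bearing ring, so nothing here supports a change beyond the scatter. The expected step is a number 7 percentage points higher from compound 1 to compound 4 (within the scatter), none beyond the scatter. Compound 4 is estimated at -85%, with a range of -98% to -45%.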

Compound 4, a percentage reported as activity, at one concentration (the size of the read-out at that concentration, not a potency): -81%
Estimate against measurement, compound 4: 4 percentage points below, within the range that was stated.
By their numbers in this assay, from the lowest: compounds 3, 1, 2 and 4 (each within the scatter of the next, the first and the last beyond it).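

For the compounds shown here, the carbonyl carbon is the first position where a one-place change gives a step beyond the scatter in this assay: a number 11 percentage points higher from compound 1 to compound 4 (beyond the scatter). The step is modest, and it shows that 3,4-difluorophenyl in place of 4-aminophenyl weakens the effect at the concentration tested, which the earlier step on the methoxy-bearing ring did not show. No measurement on hand accounts for this step.

As far as these compounds go, it remains open whether the step follows from the loss of the amine or from the entry of the two fluorines. An unsubstituted phenyl or a carboxylic acid-bearing phenyl on the same carbonyl carbon would help separate these.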